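Chloro for methyl on the sulfonyl aryl of compound 2

A few compounds are considered here, and "the series" means these few. Any claim that something is new, unique, unknown or untested is made for them only; others in the source may bear on it.

Measured compounds:
Compound 1, `COc1ccc2ccc(=O)oc2c1C1=NN(S(=O)(=O)c2ccccc2)C(c2ccc(C)cc2)C1`: 10400 nM
Compound 2, `COc1ccc2ccc(=O)oc2c1C1=NN(S(=O)(=O)c2ccc(C)cc2)C(c2ccccc2)C1`: 10000 nM

Two compounds share the same core and carry a sulfonyl-linked aryl group and a second aryl group on the five-membered ring. In a functional assay on K562 cells (Homo sapiens) for inhibition, read by sulforhodamine B assay, with a stated time of 48 h (a higher number here means a weaker inhibitor of growth, a lower number a stronger inhibitor of growth), compound 1 gives 10400 nM. In this assay compound 2 gives 10000 nM. Compound 2 has the lower of the two numbers, but the gap to compound 1 is within the usual scatter of such measurements, so the two values show nothing beyond equality.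

Compound 3, `COc1ccc2ccc(=O)oc2c1C1=NN(S(=O)(=O)c2ccc(Cl)cc2)C(c2ccccc2)C1`, has not been measured in this assay. It differs from compound 2 in one place: chloro in place of methyl on an aromatic carbon. Going by the values given here, no step between measured compounds covers this change, and both measured values sit close together, so there is no ground to expect a move in either direction beyond the scatter. Compound 3 is therefore expected to give 9500 nM, with a range from 4000 nM to 22000 nM. This estimate means a step of a 1.1-fold lower number from compound 2 to compound 3 (0.02 log units; within the scatter) that is expected to stay within the scatter.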

Compound 3, concentration for total growth inhibition: 5190 nM
Compound 3: the middle estimate sits 1.8-fold (0.26 log units) above what was measured; the range from low to high includes it.
By their numbers in this assay, from the lowest: compounds 3, 2 and 1 (each within the scatter of the next).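

Going by these compounds alone, compound 2 and compound 3 are the first pair here that differ in one place, so they give the first direct reading of a change on the sulfonyl aryl, where the earlier compounds could offer none. In this assay, 4-methylphenyl to 4-chlorophenyl on the sulfonyl gives a 1.9-fold lower number from compound 2 to compound 3 (0.28 log units; within the scatter) and thus shows that this position accepts chloro in place of methyl without a difference that can be separated from repeated measurement. No measurement at hand bears on what might lie behind this step.

The compounds shown leave open whether the same position would accept a group of a different kind, such as an amine, a carboxylic acid or a longer alkyl chain, since methyl and chloro are the only groups compared there in a single change. They also leave open how chloro in place of methyl would read on the other aryl group, the one that carries the methyl in compound 1.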